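Urea aryl ring: hydrogen in place of chloro

This account rests on a few compounds, and the source may have more. Where it says the series, first, only, none or still open, it means among the compounds named here.

Compound 2 `COc1cc(Cl)cc(-c2nn(-c3cccc(NC(=O)Nc4ccc(Cl)c(C(F)(F)F)c4)c3)cc2-c2ccncc2)c1` gives the highest number of the three measured compounds in a functional assay on HT-29 cells (Homo sapiens) for inhibition, read by sulforhodamine B assay, with a stated time of 48 h, tested at 100 uM (on this read-out lower numbers stand for a stronger effect and higher numbers for a weaker effect at the one concentration tested), at -84%. Compound 1 `O=C(Nc1cccc(-n2cc(-c3ccncc3)c(-c3cc(O)cc(Cl)c3)n2)c1)Nc1ccc(Cl)c(C(F)(F)F)c1` gives -88% in this assay, and the step of a number 4 percentage points higher from compound 1 to compound 2 (within the scatter) lies within the scatter. For the measured compounds named here, compound 3 `COc1cc(Cl)cc(-c2nn(-c3cccc(NC(=O)Nc4cc(C(F)(F)F)cc(C(F)(F)F)c4)c3)cc2-c2ccncc2)c1` gives -96%, a gap to compound 2 beyond the scatter, but no single-point step links these two.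

Compound 4 `COc1cc(Cl)cc(-c2nn(-c3cccc(NC(=O)Nc4cccc(C(F)(F)F)c4)c3)cc2-c2ccncc2)c1` differs from compound 2 by hydrogen in place of chloro on an aromatic carbon. Going by the values given here, no measured step removes a chloro, and the only measured step, on an oxygen elsewhere, does not bear on it. The expected step of a number 5 percentage points higher from compound 2 to compound 4 (within the scatter) for compound 4 is therefore small, with some chance of a weaker effect. Compound 4 is estimated at -79%, within -93% to -60%.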

Compound 4, a percentage reported as activity, at one concentration (the size of the read-out at that concentration, not a potency): -97%
Estimate against measurement, compound 4: 18 percentage points above, and the stated range ends above it.
By their numbers in this assay, from the lowest: compounds 4, 3, 1 and 2 (each within the scatter of the next, the first and the last beyond it).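

On the urea aryl ring, the chloro of the 4-chloro-3-(trifluoromethyl)phenyl group can be replaced without loss of effect in this assay: hydrogen in its place gives (a number 13 percentage points lower from compound 2 to compound 4 (beyond the scatter)), a larger step than the one on the oxygen. On the same ring, hydrogen in place of a trifluoromethyl group gives (a number 1 percentage points lower from compound 3 to compound 4 (within the scatter)), so this change shows no clear shift. Nothing at hand gives a cause for either step.

Going by these compounds, whether an amine or a nitrile on this carbon would keep the effect remains open. So does whether these steps persist at lower concentrations.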